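The source may report more compounds than this note shows. Statements on the series, on what has been measured and on what is new or still open speak of the compounds shown alone.

Measured so far:
compound 1 `CCCC(C)C(=O)Nc1c(C(O)(C(F)(F)F)C(F)(F)F)ccc2ccccc12` — in an assay on LtK cells with ATP-sensitive inward rectifier potassium channel 11 (Homo sapiens) as the target (a higher number here means that more compound is needed for the effect, a lower number that less compound is needed), compound 1 gives > 10000 nM, which is a limit of the assay and not a number.
compound 2 `CC(C)CCC(=O)Nc1c(C(O)(C(F)(F)F)C(F)(F)F)ccc2ccccc12` — in this assay compound 2 gives 49 nM.

For the measured compounds named here, compound 2 thus holds the only number in this assay; the other value shown is a limit. Going by the values given here, the one measured step, an at least 200-fold lower number from compound 1 to compound 2 (2.30 log units; beyond the scatter), replaces 1-methylbutyl with isopentyl on the carbonyl carbon, and its lower end rests on a limit (the limit of > 10000 nM in this assay, at which 1 of the 2 values shown sits).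

Compound 3 `O=C(CC1CCCC1)Nc1c(C(O)(C(F)(F)F)C(F)(F)F)ccc2ccccc12` carries cyclopentyl in place of isobutyl on a saturated chain carbon bound to a carbonyl carbon. The measured step bears on it only loosely: it shows that the shape of the saturated chain on the carbonyl carbon can shift the number strongly, but it gives no direct read on a ring in place of a branched chain. No step beyond the scatter is therefore expected in this assay.

For compound 3 the estimate is 80 nM, with a range from 20 nM to 400 nM. That estimate means an expected step of a 1.6-fold higher number from compound 2 to compound 3 (0.21 log units; within the scatter).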

Compound 3, half-maximal effective concentration: 81 nM
Beside the measured number, compound 3's estimate is 1.0-fold (0.01 log units) below it; the measured number falls inside the stated range.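

The step of a 1.7-fold higher number from compound 2 to compound 3 (0.22 log units; within the scatter) shows that in this assay this position accepts a closed cyclopentyl ring in place of the open isobutyl group, with no shift beyond the scatter. The step of an at least 120-fold lower number from compound 1 to compound 3 (2.09 log units; beyond the scatter) shows that cyclopentylmethyl on a carbonyl carbon, like isopentyl, stands far from 1-methylbutyl, so the large gap is not tied to isopentyl alone. Compound 1 holds a limit and not a number, so the size of that step rests on it: the limit of > 10000 nM in this assay, at which 1 of the 3 values shown sits.

Open remain a larger ring such as cyclohexyl or phenyl on the same saturated chain carbon, and a chain carrying an amine or a carboxylic acid. The compounds shown also give no read on a longer chain on the carbonyl carbon or on any change to the shared core.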